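Swapping propyl for methoxy on the aryl ring of compound 3

The compounds below may be only part of what the source reports. "The series", "measured", "known", "first", "only" and "open" are said of these compounds alone.

Measured compounds:
compound 1 `O=C1C=C(Nc2ccc(I)cc2)C(=O)c2c1nc1n2[C@H]2OC[C@@H](O)[C@H]2OC1` gives 2230 nM
compound 2 `CCc1ccc(NC2=CC(=O)c3nc4n(c3C2=O)[C@H]2OC[C@@H](O)[C@H]2OC4)cc1` gives 960 nM
compound 3 `CCCc1ccc(NC2=CC(=O)c3nc4n(c3C2=O)[C@H]2OC[C@@H](O)[C@H]2OC4)cc1` gives 4660 nM

All three share one core and differ only in the group on an aromatic carbon, para to a large group. In a functional assay on MCF7 cells (Homo sapiens) for inhibition, read by sulforhodamine B assay (a lower number here means a stronger inhibitor, a higher number a weaker inhibitor), compound 3 has the highest number of the three: compound 1 sits at a 2.1-fold higher number from compound 1 to compound 3 (0.32 log units; beyond the scatter), and compound 2, the lowest, at a 4.9-fold higher number from compound 2 to compound 3 (0.69 log units; beyond the scatter). So far each change at this position has moved the number beyond the scatter in one direction or the other.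

Compound 4 `COc1ccc(NC2=CC(=O)c3nc4n(c3C2=O)[C@H]2OC[C@@H](O)[C@H]2OC4)cc1` is not yet measured. It differs from compound 3 as follows: methoxy in place of propyl on an aromatic carbon. Among the compounds with values here, no measured compound carries a methoxy here, so there is no direct precedent. Within the data shown here, the steps that bear on the change are those at the same carbon: a 2.3-fold lower number from compound 1 to compound 2 (0.37 log units; beyond the scatter) and a 4.9-fold higher number from compound 2 to compound 3 (0.69 log units; beyond the scatter), both modest and beyond the scatter. The loss of propyl, the group paired with the highest number, is expected to lower the number for compound 4 by a 2.9-fold lower number from compound 3 to compound 4 (0.46 log units; beyond the scatter). Compound 4 is therefore estimated at 1600 nM, within 500 nM to 5000 nM.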

Compound 4, half-maximal inhibitory concentration: 5420 nM
Estimate against measurement, compound 4: 3.4-fold (0.53 log units) below; the whole stated range lies below it.
By their numbers in this assay, from the lowest: compound 2; then compound 1; then compounds 3 and 4 (each within the scatter of the next).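

In this assay, methoxy in place of propyl on this aromatic carbon gives a 1.2-fold higher number from compound 3 to compound 4 (0.07 log units; within the scatter) and so leaves the number unresolved between 4-propylphenyl and 4-methoxyphenyl, even though the two groups differ in their heavy atoms and hydrogen-bond acceptors. The wider steps are a 5.6-fold higher number from compound 2 to compound 4 (0.75 log units; beyond the scatter) and a 2.4-fold higher number from compound 1 to compound 4 (0.39 log units; beyond the scatter) and they leave ethyl, in compound 2, as the group with the lowest number of the four, while a number as high as that of compound 3 is no longer tied to propyl alone. Nothing shown accounts for these numbers.

The compounds shown leave open whether the low number of compound 2 is particular to ethyl, or whether methyl, butyl or an amine on this carbon would sit near it. They also leave open whether the step from propyl to methoxy would read the same with another change on the shared core.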